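Adding a Third Methoxy Group at Compound 2

A few compounds are considered here, and "the series" means these few. Any claim that something is new, unique, unknown or untested is made for them only; others in the source may bear on it.

Measured compounds:
compound 1 `COc1cc(C)c(Cl)cc1C1=NN(c2ccc(S(N)(=O)=O)cc2)C(/C=C/c2ccccc2)C1`: 52.4%
compound 2 `COc1ccc(C2CC(c3cc(Cl)c(C)cc3OC)=NN2c2ccc(S(N)(=O)=O)cc2)cc1OC`: 47.6%

The study's measurements come from a functional assay on the whole organism (strain Wistar) for inhibition, with Rattus norvegicus as the target, read by paw edema, with stated times of 30 min and 5 h, at a dose of 20 mg/kg by the oral route; on this read-out lower numbers stand for less inhibition and higher numbers for more inhibition at the one dose given (going by the name of the read-out). Here compound 1 gives 52.4% and compound 2 gives 47.6%. Going by the values given here, compound 2 carries the lower of the two numbers, but the only step to it, a number 4.8 percentage points lower from compound 1 to compound 2 (within the scatter), is within the scatter, so compound 2 and compound 1 cannot be told apart on this read-out.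

The next compound, compound 3 `COc1cc(C)c(Cl)cc1C1=NN(c2ccc(S(N)(=O)=O)cc2)C(c2ccc(OC)c(OC)c2OC)C1`, differs from compound 2 in one place: methoxy in place of hydrogen on an aromatic carbon. Among the compounds with values here, only one measured step exists, and it bears on this change only loosely, since it exchanged the whole group on the saturated ring carbon rather than adding to it; even that wholesale exchange, from a 2-phenylethenyl to a 3,4-dimethoxyphenyl group, moved the number by a number 4.8 percentage points lower from compound 1 to compound 2 (within the scatter), which is within the scatter. Within the data shown here, the addition of one methoxy group to an aryl group that already carries two is a smaller change than that exchange, and no measured step points in either direction.

Compound 3 is therefore expected to give about 48% in this assay, with a range from 35% to 62%. The estimate implies an expected step of a number 0.4 percentage points higher from compound 2 to compound 3 (within the scatter), none beyond the scatter.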

Compound 3, a percentage reported as inhibition, in the whole organism at one dose (the size of the read-out at that dose, not a potency): 21.4%
Beside the measured number, compound 3's estimate is 26.6 percentage points above it; the whole stated range lies above it.
By their numbers in this assay, from the lowest: compound 3; then compounds 2 and 1 (each within the scatter of the next).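

Methoxy in place of hydrogen on this aromatic carbon, ortho to a large group and ortho to a methoxy group, gave a number 26.2 percentage points lower from compound 2 to compound 3 (beyond the scatter) in this assay and is the first single change here to pass beyond the scatter. The earlier exchange on the saturated ring carbon had shown no such movement, whereas the 2,3,4-trimethoxyphenyl group gives a number 31 percentage points lower from compound 1 to compound 3 (beyond the scatter) and so separates itself from the 2-phenylethenyl group where the 3,4-dimethoxyphenyl group did not; on this read-out, one added methoxy group on an aryl ring already bearing two counts for more than the replacement of the whole group. No evidence at hand bears on why this single addition has so large an effect.

The compounds shown leave open whether the drop belongs to this particular aromatic carbon or to the presence of a third methoxy group anywhere on that ring. They also leave open whether a hydroxy group, a fluorine atom or an ethoxy group at the same carbon would give a similar number.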